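The compounds below may be only part of what the source reports. "The series", "measured", "known", "first", "only" and "open" are said of these compounds alone.

Of the compounds shown here, two sharing one core have been tested so far in a functional assay on HT-29 cells (Homo sapiens) for antiproliferative activity, read by MTT assay, with a stated time of 48 h; a lower number here means a stronger inhibitor of growth, a higher number a weaker inhibitor of growth. Compound 1 `COC(=O)N1N=C(c2ccccc2)CC1c1ccccc1` gives > 10000 nM, which is a limit of the assay and not a number. For the measured compounds named here, compound 2 `COC(=O)N1N=C(c2ccccc2)CC1c1ccc(OC)c(O)c1` gives 3500 nM, the only exact number available, so it is the one firm reference point in this assay.

Compound 3 `COC(=O)N1N=C(c2ccccc2)CC1c1ccc(OC)cc1` has not yet been measured. It differs from compound 2 at a single place: hydrogen in place of hydroxy on an aromatic carbon. In words, hydrogen takes the place of hydroxy on an aromatic carbon, ortho to a methoxy group and meta to a large group.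

Going by the values given here, no measured pair shows what this change does by itself, so any forecast is uncertain. A modest move towards weaker growth inhibition in this assay seems most likely, although a result within the usual scatter would be no surprise. This expectation leans on compound 1, whose > 10000 nM is a limit. The expected change is a 2.3-fold higher number from compound 2 to compound 3 (0.36 log units; beyond the scatter). For compound 3, the estimated value is 8000 nM, with an expected range of 3000 nM to 20000 nM.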

Compound 3, concentration for 50% growth inhibition: > 10000 nM
Compound 3: no number, only a limit; the forecaster's own chance of this, stated with the estimate: 45%; at least 1.2-fold (0.09 log units) between middle value and limit.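

Hydroxy at this position now has a measured step of its own: in this assay, hydrogen in place of hydroxy on an aromatic carbon, ortho to a methoxy group, gives an at least 2.8-fold higher number from compound 2 to compound 3 (0.45 log units; beyond the scatter). Of this pair, only compound 2, which carries the hydroxy group, has a firm value, so the methoxy group that stays in compound 3 does not by itself give a measurable value. The step is therefore only a minimum, and its true size stays unknown, because compound 3 sits at a limit of the assay and not at a number: the limit of > 10000 nM in this assay, at which 2 of the 3 values shown sit.

As far as these compounds go, the step from compound 1 to compound 3, methoxy in place of hydrogen on an aromatic carbon, cannot be read, with a limit on both sides, so the methoxy group's own contribution remains open. For the compounds shown here, also open is whether hydroxy is the only group that works at this position, which an amine or a carboxylic acid at the same place in this assay would begin to answer.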